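This account rests on a few compounds, and the source may have more. Where it says the series, first, only, none or still open, it means among the compounds named here.

Of the compounds shown here, three have been measured in an assay on isolated protein for inhibition of Aromatase (Homo sapiens), read by fluorescence, using NADPH, with a stated time of 30 min, tested at 50 uM; a higher number here means more inhibition at the concentration tested (going by the name of the read-out), a lower number less inhibition. Compound 1 `Cn1c(-c2ccc(Cl)c(Cl)c2)cc2cc([N+](=O)[O-])ccc21` gives 34%. Compound 2 `Cn1c(-c2ccccc2)cc2cc([N+](=O)[O-])ccc21` gives 77%, the highest of the three. Compound 3 `O=[N+]([O-])c1ccc2[nH]c(-c3ccc(Cl)c(Cl)c3)cc2c1` gives 7.59%. The difference between the cores of compound 1 and compound 2 is not broken down here. Compound 3 arises from compound 1 by hydrogen in place of methyl on an aromatic nitrogen, and this step gives a number 26.4 percentage points lower from compound 1 to compound 3 (beyond the scatter). Compound 4 `O=[N+]([O-])c1ccc2[nH]c(-c3ccccc3)cc2c1` is not yet measured; it arises from compound 2 by hydrogen in place of methyl on an aromatic nitrogen. This is the same kind of change, though around the place the ring atom bears a phenyl group (6 heavy atoms) rather than a group of 8 heavy atoms. Because compound 1 to compound 3 gave a number 26.4 percentage points lower from compound 1 to compound 3 (beyond the scatter), a comparable step, a number 27 percentage points lower from compound 2 to compound 4 (beyond the scatter), is expected from compound 2 to compound 4. Compound 4 is therefore estimated at 50%, likely between 30% and 70%.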

Compound 4, a percentage reported as inhibition, at one concentration (the size of the read-out at that concentration, not a potency): 77.7%
Compound 4: middle estimate off by 27.7 percentage points, on the low side, and the stated range ends below it.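

On the core of compound 2, hydrogen in place of methyl on the aromatic nitrogen gives a number 0.7 percentage points higher from compound 2 to compound 4 (within the scatter). The effect of this change therefore did not carry over unchanged from one core to the other in this assay: the same change on two cores in this assay, a number 26.4 percentage points lower (beyond the scatter) from compound 1 to compound 3 and a number 0.7 percentage points higher (within the scatter) from compound 2 to compound 4, 27.1 percentage points apart, beyond the scatter of two such steps

These two pairs do not show which feature of the cores sets the results apart, or how the change would behave on a third core.

The compounds shown carry only methyl or hydrogen on that nitrogen, leaving open what a longer chain, such as ethyl, or a chain ending in an amine would do there. Also open, as far as these compounds go, is how a nitrile or a carboxylic acid would compare with the nitro group.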